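The source may hold more compounds than are shown below. What is called first, only, known or untested is meant among the compounds shown, and "the series" means these compounds.

Working notes on the series. Among the compounds with values here, in an ADME assay on microsomes (Homo sapiens) for metabolic stability (on this read-out lower numbers stand for a shorter-lived compound and higher numbers for a longer-lived compound), compound 1 (`O=C(c1ccccc1)N1CCC(C(=O)N2N=CCC2c2ccccc2)CC1`) gives 1.72 h, the only true number so far. Compound 2 (`O=C(c1cnco1)N1CCC(C(=O)N2N=CC[C@H]2c2ccccc2)CC1`) reads > 3 h in this assay, which is a limit and not a number. Compound 3 (`O=C(c1cscn1)N1CCC(C(=O)N2N=CC[C@H]2c2ccccc2)CC1`) reads > 3 h, again a limit. For the set as a whole, this leaves (the limit of > 3 h in this assay, at which 2 of the 3 values shown sit).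

The next compound is compound 4 (`O=C(c1cn[nH]c1)N1CCC(C(=O)N2N=CCC2c2ccccc2)CC1`), and its change from compound 1 is 1H-pyrazol-4-yl in place of phenyl on a carbonyl carbon. In words, 1H-pyrazol-4-yl stands in place of phenyl on a carbonyl carbon, so benzoyl becomes (1H-pyrazol-4-yl)carbonyl.

Within the data shown here, the only measured step between neighbours is a step that the two limits leave unreadable from compound 2 to compound 3, and it supplies no size to carry over. Among the measured compounds shown here, no measured step starts from compound 1, so the guide is indirect. Compound 3, which also has a five-membered aromatic ring with 2 hetero atoms on the carbonyl carbon, reads > 3 h, and that limit supports a lean toward the longer-lived side. The lean stays modest, since compound 3 has a defined stereocentre and compound 4 does not.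

The expected change is a 1.5-fold higher number from compound 1 to compound 4 (0.18 log units; within the scatter), a small rise that may not clear the usual scatter. For compound 4 the estimated half-life is 2.6 h, with an expected range of 1.3 h to 5 h.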

Compound 4, half-life: > 2.75 h
Compound 4 gave a limit, no number; the forecaster's own chance of this, stated with the estimate: 35%; at least 1.0-fold (0.02 log units) between middle value and limit.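

In this assay compound 4 reads > 2.75 h, which is a limit of the assay and not a number. With 1H-pyrazol-4-yl in place of phenyl on a carbonyl carbon and the rest of the structure unchanged, the series now has its first readable step at this position: an at least 1.5-fold higher number from compound 1 to compound 4 (0.20 log units; that floor lies within the scatter). Only a floor is known, and since it lies within the scatter, the change is not yet shown to go beyond the scatter, although its true size may be larger; the earlier step at this position, between compound 2 and compound 3, cannot be read.

On these data alone, the true half-life of compound 4, and with it the full size of the step, stays open as long as this value remains a limit: the limit of > 2.75 h in this assay, at which 1 of the 4 values shown sits. Also open is how a pyridin-3-yl group, or a simple alkyl chain, in place of phenyl on the same carbonyl carbon would read in this assay, and whether the step would hold with a defined stereocentre in the core.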